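The source may report more compounds than this note shows. Statements on the series, on what has been measured and on what is new or still open speak of the compounds shown alone.

Measured so far:
compound 1 `CCN(Cc1cccs1)C(=O)COc1ccc(C(F)(F)F)cc1` gives 236 nM;
compound 2 `Cc1ccc(/C=C/C(=O)N(Cc2cccs2)c2ccn[nH]2)cc1` gives 0.004 nM;
compound 3 `CCN(Cc1cccs1)C(=O)/C=C/c1ccc(C)cc1` gives 2 nM.

In an assay on HEK293 cells for agonist activity at transient receptor potential cation channel subfamily M member 8 (Homo sapiens), read by fluorescence and calcium flux, with a stated time of 15 min (a higher number here means that more compound is needed for the effect, a lower number that less compound is needed), compound 1 stands highest of the three numbers; compound 3 is nearest and compound 2 furthest, both well beyond the scatter. For the measured compounds named here, the only step measured in one place is a 500-fold higher number from compound 2 to compound 3 (2.70 log units; beyond the scatter), which concerns the amide-type nitrogen and not the six-membered aromatic ring. Compound 4 `CCN(Cc1cccs1)C(=O)COc1ccc(C(=O)O)cc1` differs from compound 1 by carboxy in place of trifluoromethyl on an aromatic carbon. No measured step touches this position, so nothing shown bears directly on the change. The expectation is nonetheless a higher number, beyond the scatter, of roughly an 8.5-fold higher number from compound 1 to compound 4 (0.93 log units; beyond the scatter). Compound 4 is therefore estimated at 2000 nM, within 500 nM to 10000 nM, in this assay.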

Compound 4, half-maximal effective concentration: "not active" (no number reported)
Nothing numeric was reported for compound 4, so the estimate cannot be set against anything.
By their numbers in this assay, from the lowest: compound 2; then compound 3; then compound 1.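

Compound 4 is reported as "not active" with no number, so no step from compound 1 to compound 4 can be read, and nothing available explains this result. The compounds shown leave open how large the change from trifluoromethyl to carboxy is.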